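Chloro for methyl: expectation for compound 3

The source may report more compounds than this note shows. Statements on the series, on what has been measured and on what is new or still open speak of the compounds shown alone.

The shared core is assayed for growth inhibition in a functional assay on HT-29 cells (Homo sapiens) for cytotoxicity, read by MTT assay, with a stated time of 72 h; a higher number here means a weaker inhibitor of growth, a lower number a stronger inhibitor of growth. Compound 1 `N#C[Se]c1ccc(NC(=O)Oc2ccc(F)cc2)cc1` gives 37600 nM in this assay. Compound 2 `Cc1ccc(OC(=O)Nc2ccc([Se]C#N)cc2)cc1`, which carries a methyl in place of fluoro on an aromatic carbon, gives 38800 nM in this assay. The step of a 1.0-fold higher number from compound 1 to compound 2 (0.01 log units; within the scatter) lies within the scatter, so compound 2 sits level with compound 1 on the two numbers shown, neither separable from the other.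

Compound 3 `N#C[Se]c1ccc(NC(=O)Oc2ccc(Cl)cc2)cc1` is not yet measured. It differs from compound 2 by chloro in place of methyl on an aromatic carbon. Among the compounds with values here, the one measured step that bears on this change is a 1.0-fold higher number from compound 1 to compound 2 (0.01 log units; within the scatter), where exchanging one small group for another on that aromatic carbon left the number essentially unmoved. Nothing in the series speaks directly to a chloro group. On that basis a step of no more than the scatter is expected for compound 3, in no particular direction, namely a 1.0-fold lower number from compound 2 to compound 3 (0.01 log units; within the scatter). The estimate for compound 3 in this assay is 38000 nM, with a range from 19000 nM to 76000 nM.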

Compound 3, concentration for total growth inhibition: 40300 nM
Estimate against measurement, compound 3: 1.1-fold (0.03 log units) below; the measured number falls inside the stated range.
By their numbers in this assay, from the lowest: compounds 1, 2 and 3 (each within the scatter of the next).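

In this assay, the step of a 1.0-fold higher number from compound 2 to compound 3 (0.02 log units; within the scatter) and the step of a 1.1-fold higher number from compound 1 to compound 3 (0.03 log units; within the scatter) both lie within the scatter, so chloro joins methyl and fluoro on the aromatic carbon para to a large group with no separation among the three compounds. Within the data shown here, the earlier compounds offered only one exchange at this position, whereas all three pairings among fluoro, methyl and chloro are now available, and none of them moves the number beyond the scatter. No measurement shown here accounts for this level behaviour.

Still open, going by these compounds, is whether this position stays as flat with a group unlike these three, such as an amine, a carboxylic acid, a methoxy group or a longer chain, or with the aromatic carbon left bearing only hydrogen. The three compounds also share the carbamate link and the selenocyanate group, so they do not show how the number responds to a change at either of those places, or whether a change there would make the group on this aromatic carbon matter.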